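This account rests on a few compounds, and the source may have more. Where it says the series, first, only, none or still open, it means among the compounds named here.

In a functional assay on A549 cells (Homo sapiens) for inhibition, read by sulforhodamine B assay, with a stated time of 72 h (a lower number here means a stronger inhibitor, a higher number a weaker inhibitor), compound 3 (`COc1cc2c(Nc3cccc(Br)c3)ncnc2cc1OCCCn1ccnc1[N+](=O)[O-]`) gives 13500 nM. Compound 2 (`COc1cc2c(Nc3ccc(OCc4cccc(F)c4)c(Cl)c3)ncnc2cc1OCCCCCn1ccnc1[N+](=O)[O-]`) gives 19900 nM, within the scatter of compound 3, while compound 1 (`COc1cc2c(Nc3ccc(F)c(Cl)c3)ncnc2cc1OCCCn1ccnc1[N+](=O)[O-]`) gives 5910 nM.

Compound 4 (`COc1cc2c(Nc3cccc(Br)c3)ncnc2cc1OCCCCCn1ccnc1[N+](=O)[O-]`) has not yet been measured. It keeps the 3-bromophenyl group of compound 3, with 2-(2-nitro-1H-imidazol-1-yl)ethyl in place of 2-nitro-1H-imidazol-1-yl on a saturated chain carbon, three bonds along the chain from an oxygen on an aromatic ring.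

Going by the values given here, the one measured step, a 2.3-fold higher number from compound 1 to compound 3 (0.36 log units; beyond the scatter), is modest and lies beyond the scatter, but it concerns the group on nitrogen and leaves the chain unchanged. Among the compounds with values here, no measured pair isolates the chain change. Compound 2, at 19900 nM, carries the chain of compound 4 but has a different group on nitrogen, so it is only indirect evidence. Its value nevertheless gives no sign that the longer chain brings a large change in this assay, and no step beyond the scatter is expected, in either direction.

The estimated step of a 1.1-fold higher number from compound 3 to compound 4 (0.05 log units; within the scatter) is expected to stay within the scatter. For compound 4 the expected value is 15000 nM, with an estimated range of 6500 nM to 35000 nM.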

Compound 4, half-maximal inhibitory concentration: 8780 nM
Compound 4: the middle estimate sits 1.7-fold (0.23 log units) above what was measured; low and high end bracket the measured number.
By their numbers in this assay, from the lowest: compounds 1, 4, 3 and 2 (each within the scatter of the next, the first and the last beyond it).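

In this assay, going by these compounds alone, the change to 2-(2-nitro-1H-imidazol-1-yl)ethyl in place of 2-nitro-1H-imidazol-1-yl on a saturated chain carbon, three bonds along the chain from an oxygen on an aromatic ring, gives a 1.5-fold lower number from compound 3 to compound 4 (0.19 log units; within the scatter) and is the first direct reading of this chain change. With the 3-bromophenyl group held fixed, the two chains cannot be told apart in this assay, so this position accepts the extension without a measurable penalty or gain, though the reading rests on a single pair. No accompanying data bear on this result.

Within the data shown here, whether the same chain change stays within the scatter with other groups on nitrogen, such as the 3-chloro-4-fluorophenyl group, remains open, since only one pair isolates it. Also open, going by these compounds, is how this assay responds to a longer chain than 3-(2-nitro-1H-imidazol-1-yl)propyl, or to a morpholine at the chain end in place of the 2-nitro-1H-imidazol-1-yl group.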